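The source may hold more compounds than are shown below. What is called first, only, known or untested is meant among the compounds shown, and "the series" means these compounds.

In a functional assay on HCT-116 cells (Homo sapiens) for inhibition (a lower number here means a stronger inhibitor, a higher number a weaker inhibitor), compound 1 `CCNC(=O)c1noc(-c2cc(C(C)C)c(O)cc2O)c1-c1cc(CNCCO)no1` gives 111 nM, and compound 2 `CCNC(=O)c1noc(-c2cc(C(C)C)c(O)cc2O)c1-c1cc(C(=O)O)no1` has the entry "not determined" (no result reported). Going by the values given here, compound 3 `CCNC(=O)c1noc(-c2cc(C(C)C)c(O)cc2O)c1-c1cc[nH]n1`, at 36 nM, holds the lowest number so far, with compound 1 as its only numeric neighbour. Compound 4 `CCNC(=O)c1noc(-c2cc(C(C)C)c(O)cc2O)c1-c1ccn(C(C)C)n1` differs from it by isopropyl in place of hydrogen on an aromatic nitrogen. Among the compounds with values here, the one measured step touching this ring position is a 3.1-fold lower number from compound 1 to compound 3 (0.49 log units; beyond the scatter), a modest change that exchanged the whole ring substituent, so it bears only indirectly. Within the data shown here, no measured compound carries a group on that nitrogen. A modest rise of similar size is therefore expected, held loosely, as a 2.2-fold higher number from compound 3 to compound 4 (0.35 log units; beyond the scatter). For compound 4 the estimated value is 80 nM, with an expected range of 20 nM to 300 nM.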

Compound 4, half-maximal inhibitory concentration: 19 nM
Compound 4: middle estimate off by 4.2-fold (0.62 log units), on the high side; measured number outside the range, below it.
By their numbers in this assay, from the lowest: compounds 4 and 3 (each within the scatter of the next); then compound 1.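

Isopropyl on the aromatic nitrogen, where compound 3 carries hydrogen, brings no reading of change in this assay, with a 1.9-fold lower number from compound 3 to compound 4 (0.28 log units; within the scatter), so this position accepts a group of this size without loss. The 1-isopropyl-1H-pyrazol-3-yl group also stands clear of the larger substituent of compound 1, with a 5.8-fold lower number from compound 1 to compound 4 (0.77 log units; beyond the scatter) as the step. No supporting evidence is available to explain either step.

Open, from the compounds shown here alone, is how far this nitrogen accepts other groups, such as methyl, a longer alkyl chain or phenyl. Going by these compounds, whether any of these would move the number beyond the scatter also remains unknown.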